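Estimating compound 4 after a change of aryl group

This account rests on a few compounds, and the source may have more. Where it says the series, first, only, none or still open, it means among the compounds named here.

Measured in a functional assay on C8166 cells (Homo sapiens) for cytotoxicity, read by MTT assay; a lower number here means that less compound is tolerated, a higher number that more compound is tolerated
compound 1 `Cc1cc(S(N)(=O)=O)ccc1NC(=O)COc1ccc(Cl)cc1NC(=O)c1ccccc1` gives 207000 nM
compound 2 `COc1ccc(C(=O)Nc2cc(Cl)ccc2OCC(=O)Nc2ccc(S(N)(=O)=O)cc2C)cc1` gives 69500 nM
compound 3 `Cc1ccc(C)c(C(=O)Nc2cc(Cl)ccc2OCC(=O)Nc2ccc(S(N)(=O)=O)cc2C)c1` gives 79700 nM

Compound 3, at 79700 nM, belongs with compound 2 in the lower pair of these three values. The next compound, compound 4 `Cc1cc(S(N)(=O)=O)ccc1NC(=O)COc1ccc(Cl)cc1NC(=O)c1ccc(Cl)c(Cl)c1`, differs from it by 3,4-dichlorophenyl in place of 2,5-dimethylphenyl on a carbonyl carbon. Two modest steps led away from the unsubstituted phenyl: a 3.0-fold lower number from compound 1 to compound 2 (0.47 log units; beyond the scatter) and a 2.6-fold lower number from compound 1 to compound 3 (0.41 log units; beyond the scatter). For the measured compounds named here, exchanging one substituted aryl group for another gave a 1.1-fold higher number from compound 2 to compound 3 (0.06 log units; within the scatter), the closest precedent, so no step beyond the scatter is expected in this assay. Going by the values given here, none of the measured compounds carries chlorine on this group, which widens the range. The expected change is a 1.1-fold lower number from compound 3 to compound 4 (0.03 log units; within the scatter). For compound 4 the estimated value is 75000 nM, within an expected range from 28000 nM to 200000 nM.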

Compound 4, half-maximal cytotoxic concentration: 158000 nM
The estimate for compound 4 lay 2.1-fold (0.32 log units) below the measured number; the range from low to high includes it.
By their numbers in this assay, from the lowest: compounds 2, 3, 4 and 1 (each within the scatter of the next, the first and the last beyond it).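

In this assay, for the compounds shown here, 3,4-dichlorophenyl, the first chlorine-bearing group at this position, stays within the scatter of both 2,5-dimethylphenyl (a 2.0-fold higher number from compound 3 to compound 4 (0.30 log units; within the scatter)) and the unsubstituted phenyl (a 1.3-fold lower number from compound 1 to compound 4 (0.12 log units; within the scatter)). Only against 4-methoxyphenyl does it go beyond the scatter (a 2.3-fold higher number from compound 2 to compound 4 (0.36 log units; beyond the scatter)), so a substituted aryl group here need not lie beyond the scatter of phenyl: compound 2 and compound 3 do, compound 4 does not. No evidence is available to explain these differences. From the compounds shown here alone, it remains open where an aryl group carrying an amine or a carboxylic acid would fall in this assay.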